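A few compounds are considered here, and "the series" means these few. Any claim that something is new, unique, unknown or untested is made for them only; others in the source may bear on it.

Working notes on the series.

Compound 1 `CSc1cc(C)nc(SC)c1NC(=O)N(Cc1ccccc1)Cc1cccc(-c2ccnn2C)c1` is measured in a functional assay on a cell-free system (plasma) with sterol O-acyltransferase, Soat (Rattus norvegicus) as the target; on this read-out higher numbers stand for an effect only at larger amounts of compound and lower numbers for an effect already at smaller amounts. In this assay compound 1 gives < 1 mg/kg, which is a limit of the assay, as the limit of < 1 mg/kg in this assay, at which 1 of the 3 values shown sits, states. Compound 2 `CSc1cc(C)nc(SC)c1NC(=O)N(Cc1ccccc1)Cc1cccc(-c2cnn(C)c2)c1` carries 1-methyl-1H-pyrazol-4-yl in place of 1-methyl-1H-pyrazol-5-yl on an aromatic carbon. In this assay compound 2 gives > 0.1 mg/kg, again a limit, as the limit of > 0.1 mg/kg in this assay, at which 1 of the 3 values shown sits, states. The step that the limit leaves unreadable from compound 1 to compound 2 is therefore not readable in size.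

Compound 3 `Cc1cc(C)c(NC(=O)N(Cc2cccc(-c3ccnn3C)c2)C2CCCCCC2)c(C)c1` has a different core; how the two cores differ is not broken down here. In this assay compound 3 gives > 1 mg/kg, a limit, as the limit of > 1 mg/kg in this assay, at which 1 of the 3 values shown sits, states.

Compound 4 `Cc1cc(C)c(NC(=O)N(Cc2cccc(-c3cnn(C)c3)c2)C2CCCCCC2)c(C)c1` carries 1-methyl-1H-pyrazol-4-yl in place of 1-methyl-1H-pyrazol-5-yl on an aromatic carbon, the same change as from compound 1 to compound 2. For compound 4 the step that the limit leaves unreadable from compound 3 to compound 4 is expected to stay small, since the measured step is unreadable and compound 3 sits at a limit with > 1 mg/kg. Compound 4 is estimated at 3 mg/kg, between 1 mg/kg and 10 mg/kg, with a limit likely.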

Compound 4, dose for half-maximal effect: < 1 mg/kg
Compound 4: a limit, no number (the forecaster's own chance of this, stated with the estimate: 60%); middle value at least 3.0-fold (0.47 log units) away from the limit.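

On the core of compound 3, 1-methyl-1H-pyrazol-4-yl in place of 1-methyl-1H-pyrazol-5-yl gives in this assay a number no higher from compound 3 to compound 4 (the limit leaves the size open), and both values are limits of the assay, not numbers. On the core of compound 1 the same change joins two limits as well and cannot be read, not even in direction. The change is therefore seen to give a number no higher on one core only; neither its size nor whether it carries over from one core to the other is shown.

Numbers for these four compounds on either side of the limits remain open. Also open, from the compounds shown here alone, is what an amine or a carboxylic acid would give in place of the methylpyrazole group on either core.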